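Methyl-to-ethyl change on a quinolinone amine series

The source may report more compounds than this note shows. Statements on the series, on what has been measured and on what is new or still open speak of the compounds shown alone.

Compound 3 `Cc1ccc2[nH]c(=O)c(CN(Cc3ccc(F)cc3)Cc3ccc(-c4ccccc4)cc3)cc2c1` was tested in a toxicity assay on MDCK cells (Canis lupus familiaris) for cytotoxicity, read by crystal violet staining, with a stated time of 48 h; a lower number here means that less compound is tolerated, a higher number that more compound is tolerated. In this assay compound 3 gives only a limit, > 5000 nM. Two other members of the series frame it. Compound 1 `CCc1ccc2[nH]c(=O)c(CN(Cc3ccc(F)cc3)Cc3ccc(C(C)(C)C)cc3)cc2c1` also reaches only a limit in this assay, > 33000 nM. Compound 2 `CCc1ccc2[nH]c(=O)c(CN(Cc3ccc(F)cc3)Cc3ccc4ccccc4c3)cc2c1` likewise gives only a limit, > 5000 nM. Within the data shown here, the sole step between measured neighbours is a step that the two limits leave unreadable from compound 1 to compound 2. Its size cannot be read, as both ends are limits. Of the three values shown, one sits at the limit of > 33000 nM in this assay, at which 1 of the 3 values shown sits, and two sit at the limit of > 5000 nM in this assay, at which 2 of the 3 values shown sit.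

Compound 4 `CCc1ccc2[nH]c(=O)c(CN(Cc3ccc(F)cc3)Cc3ccc(-c4ccccc4)cc3)cc2c1` differs from compound 3 by methyl in place of hydrogen on a saturated chain carbon bound to an aromatic carbon, which amounts to methyl to ethyl when read one bond further out. Among the measured compounds shown here, no measured step bears directly on this change, and none of the measured values is a number rather than a limit. The step from compound 3 to compound 4 is therefore expected to be a step that the limit leaves unreadable from compound 3 to compound 4, no change beyond the scatter. Compound 4 is estimated at 30000 nM in this assay, between 5000 nM and 100000 nM, most likely again reported as a limit.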

Compound 4, half-maximal cytotoxic concentration: > 5000 nM
Compound 4: no number, only a limit; the forecaster's own chance of this, stated with the estimate: 80%; the middle value does not contradict the limit.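

In this assay, among these compounds, compound 4 gives > 5000 nM, which is a limit and not a number, so no step from compound 1, compound 2 or compound 3 to compound 4 can be read. The compounds shown leave open where the half-maximal cytotoxic concentration of any of the four lies, and whether methyl to ethyl shifts it at all.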